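Adding a Methyl to the Ring Amide of Compound 3

This account rests on a few compounds, and the source may have more. Where it says the series, first, only, none or still open, it means among the compounds named here.

Measured so far in a functional assay on the whole organism (strain Wister albino) for inhibition, with Rattus norvegicus as the target, read by paw edema, with stated times of 1 h and 3 h, at a dose of 50 mg/kg by the intraperitoneal route; a higher number here means more inhibition at the dose given (going by the name of the read-out), a lower number less inhibition:
compound 1 `CN1C/C(=C\c2ccccc2)C(=O)[C@]2(C1)[C@@H](c1ccccc1)CN(C)[C@@]21C(=O)Nc2ccccc21` gives 71.4%
compound 2 `CN1C/C(=C\c2ccccc2)C(=O)[C@]2(C1)[C@@H](c1ccccc1)CN(C)[C@@]21C(=O)N(C)c2ccccc21` gives 75.6%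
compound 3 `CN1C/C(=C\c2ccc(Br)cc2)C(=O)[C@]2(C1)[C@@H](c1ccc(Br)cc1)CN(C)[C@@]21C(=O)Nc2ccccc21` gives 65.2%

Compound 3 holds the lowest of the three numbers in this assay, but its gap to compound 1 is within the scatter; only its gap to compound 2 lies beyond it. Compound 4 `CN1C/C(=C\c2ccc(Br)cc2)C(=O)[C@]2(C1)[C@@H](c1ccc(Br)cc1)CN(C)[C@@]21C(=O)N(C)c2ccccc21` differs from compound 3 by methyl in place of hydrogen on an amide-type nitrogen in a ring. For the measured compounds named here, one measured step bears on this change: a number 4.2 percentage points higher from compound 1 to compound 2 (within the scatter). That step lies within the scatter, so the same change made on the core of compound 3 is expected to produce only a small shift, if any, in this assay, estimated as a number 3.8 percentage points higher from compound 3 to compound 4 (within the scatter). Compound 4 is therefore estimated at 69%, with a range from 60% to 78%. This rests on a single step, and no measurement shows whether the core of compound 3 answers to the change in the same way as the core of compound 1.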

Compound 4, a percentage reported as inhibition, in the whole organism at one dose (the size of the read-out at that dose, not a potency): 47.6%
The estimate for compound 4 lay 21.4 percentage points above the measured number; the whole stated range lies above it.
By their numbers in this assay, from the lowest: compound 4; then compounds 3, 1 and 2 (each within the scatter of the next, the first and the last beyond it).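

In this assay, methyl in place of hydrogen on the amide-type nitrogen in a ring proves not to be a neutral change on every core: on the core of compound 3 it gives a number 17.6 percentage points lower from compound 3 to compound 4 (beyond the scatter). For the compounds shown here, on this core, then, the form with the amide hydrogen, compound 3, holds the higher number, a difference the earlier compounds gave no sign of. What the change does at this position depends on the core that carries it: the same change on two cores in this assay, a number 4.2 percentage points higher (within the scatter) from compound 1 to compound 2 and a number 17.6 percentage points lower (beyond the scatter) from compound 3 to compound 4, 21.8 percentage points apart, beyond the scatter of two such steps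

The compounds shown leave open which feature of the two cores sets this difference, and each core offers only one pair to judge by. They also leave open whether an ethyl group, an acetyl group or a longer chain on the same nitrogen would follow the methyl on either core.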